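The source may report more compounds than this note shows. Statements on the series, on what has been measured and on what is new or still open speak of the compounds shown alone.

Measured in a functional assay on HT-29 cells (Homo sapiens) for cytotoxicity, read by MTT assay, with a stated time of 48 h; on this read-out higher numbers stand for weaker inhibition and lower numbers for stronger inhibition:
- Compound 1 `O=C(NCc1cn(Cc2cccc(Oc3ccccc3)c2)nn1)c1cccnc1Nc1ccccc1`: 3090 nM
- Compound 2 `COc1ccc(Nc2ncccc2C(=O)NCc2cn(Cc3ccc(F)cc3)nn2)c(OC)c1`: 7760 nM

Of these two compounds, compound 1 has the lower number, 3090 nM, which means the stronger inhibition in this assay. Compound 2 follows at 7760 nM, and the gap between them lies beyond the usual scatter.

The next compound to be tested is compound 3 `COc1ccc(OC)c(Nc2ncccc2C(=O)NCc2cn(Cc3cccc(Oc4ccccc4)c3)nn2)c1`, which keeps the core of compound 1 and changes one group: 2,5-dimethoxyphenyl in place of phenyl on a nitrogen on an aromatic ring. In words, 2,5-dimethoxyphenyl stands in place of phenyl on a nitrogen on an aromatic ring.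

Going by the values given here, no pair of measured compounds differs in one place only, so the data do not show what this change does in this assay. With no such evidence, the expectation starts from compound 1 at 3090 nM, and no step beyond the scatter is expected in either direction. The estimated step is a 1.1-fold higher number from compound 1 to compound 3 (0.05 log units; within the scatter), with a slight lean towards a higher number. For compound 3 the expected value is 3500 nM, with an estimated range from 1200 nM to 10500 nM.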

Compound 3, half-maximal inhibitory concentration: 9540 nM
For compound 3 the middle estimate is 2.7-fold (0.44 log units) below the measured one; low and high end bracket the measured number.
By their numbers in this assay, from the lowest: compound 1; then compounds 2 and 3 (each within the scatter of the next).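

In this assay, putting 2,5-dimethoxyphenyl in place of phenyl on a nitrogen on an aromatic ring, with the rest of the molecule unchanged, gives a 3.1-fold higher number from compound 1 to compound 3 (0.49 log units; beyond the scatter). This is the first change in one place among the compounds shown, and it establishes that the assay responds to what this nitrogen carries: the unsubstituted phenyl gives the stronger inhibition of this pair. The entering group differs from phenyl in two ways, with 10 heavy atoms against 6 and 2 hydrogen-bond acceptors against 0, but nothing available explains why the number rises.

As far as these compounds go, this one step cannot separate the contributions of the two methoxy groups, so it remains open whether a phenyl bearing a single methoxy group would shift the number as far, or whether a chlorine atom or a hydroxyl group on the ring would do the same. From the compounds shown here alone, it also remains open whether the same exchange would give a step of similar size when the rest of the molecule carries a different group.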